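This account rests on a few compounds, and the source may have more. Where it says the series, first, only, none or still open, it means among the compounds named here.

Measured in a functional assay on the whole organism (strain Sprague-Dawley) for inhibition, with Rattus norvegicus as the target, with a stated time of 10 min; on this read-out lower numbers stand for an effect already at smaller amounts and higher numbers for an effect only at larger amounts of compound:
- compound 1 `COc1ccccc1-c1ncc(C(=O)O)c(=O)[nH]1`: 10 mg/kg
- compound 2 `C=CCOc1ccccc1-c1ncc(C(=O)O)c(=O)[nH]1`: 0.5 mg/kg

Compound 2 holds the lower of the two numbers. Compound 3 `O=C(O)c1cnc(-c2ccccc2OCc2ccccc2)[nH]c1=O` has phenyl in place of vinyl on a saturated chain carbon bound to an oxygen on an aromatic ring. Going by the values given here, only one measured step touches this place, a 20-fold lower number from compound 1 to compound 2 (1.30 log units; beyond the scatter), a large step beyond the scatter. No phenyl has been measured there, so the direction stays uncertain. Since the lower number is hard to improve on, a moderate loss seems likeliest. The expected change in this assay is a 3.0-fold higher number from compound 2 to compound 3 (0.48 log units; beyond the scatter). For compound 3 the estimate is 1.5 mg/kg, within 0.3 mg/kg to 8 mg/kg.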

Compound 3, dose for 50% inhibition: 5 mg/kg
Compound 3: middle estimate off by 3.3-fold (0.52 log units), on the low side; low and high end bracket the measured number.
By their numbers in this assay, from the lowest: compound 2; then compounds 3 and 1 (each within the scatter of the next).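

In this assay, phenyl in place of vinyl gives a 10-fold higher number from compound 2 to compound 3 (1.00 log units; beyond the scatter) and so shows that the gain seen with vinyl at this place does not extend to every group put there. Phenyl in place of hydrogen gives a 2.0-fold lower number from compound 1 to compound 3 (0.30 log units; within the scatter) and leaves this pair indistinguishable in this read-out. Nothing available explains why vinyl and phenyl differ here.

Going by these compounds, whether the double bond of allyl is needed remains open, since a saturated propyl group would be the direct comparison. On these data alone, how a longer chain or an amine on the chain would behave also remains open.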